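A Ring Swap on the Amide-Type Nitrogen

The compounds below may be only part of what the source reports. "The series", "measured", "known", "first", "only" and "open" are said of these compounds alone.

Measured so far:
compound 1 `CCNc1cc(-c2ccc(NC(=O)Nc3cccc(Cl)c3)cc2C(F)(F)F)ccn1` — 94.9%
compound 2 `CCNc1cc(-c2ccc(NC(=O)Nc3ccc(C(F)(F)F)cc3)cc2C(F)(F)F)ccn1` — 82.9%

In an assay on isolated protein for inhibition of serine/threonine-protein kinase PLK1 (Homo sapiens), read by radiometric assay and 33P incorporation, with a stated time of 40 min, tested at 20 uM, in the presence of a further agent that is not named here (a higher number here means more inhibition at the concentration tested (going by the name of the read-out), a lower number less inhibition), compound 1 gives 94.9%, and compound 2 gives 82.9%. Compound 2 thus stands lowest of the two, the gap being a number 12 percentage points lower from compound 1 to compound 2 (beyond the scatter). Compound 3 `CCNc1cc(-c2ccc(NC(=O)Nc3c(C)cccc3C)cc2C(F)(F)F)ccn1` differs from compound 2 by 2,6-dimethylphenyl in place of 4-(trifluoromethyl)phenyl on an amide-type nitrogen. Among the measured compounds shown here, the only measured step, a number 12 percentage points lower from compound 1 to compound 2 (beyond the scatter), also exchanged one ring for another on this nitrogen and was modest; no measured compound carries a 2,6-dimethylphenyl group. No step beyond the scatter is therefore expected. Compound 3 is estimated at 80%, within 55% to 95%. The expected step is a number 2.9 percentage points lower from compound 2 to compound 3 (within the scatter).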

Compound 3, a percentage reported as inhibition, at one concentration (the size of the read-out at that concentration, not a potency): 59.2%
Beside the measured number, compound 3's estimate is 20.8 percentage points above it, and the stated range covers the measured number.
By their numbers in this assay, from the lowest: compound 3; then compound 2; then compound 1.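

In this assay the ring on the amide-type nitrogen proves more sensitive than the earlier pair showed. Bringing in 2,6-dimethylphenyl gives a number 23.7 percentage points lower from compound 2 to compound 3 (beyond the scatter) and also a number 35.7 percentage points lower from compound 1 to compound 3 (beyond the scatter) and this second step is the largest seen at this position. No measurement here accounts for the drop.

As far as these compounds go, it remains open whether a single methyl, as in 2-methylphenyl, would give a similar step or whether both methyl groups are needed. From the compounds shown here alone, how an unsubstituted phenyl or a ring bearing an amine would read on this nitrogen also remains open.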